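The compounds below may be only part of what the source reports. "The series", "measured", "known", "first", "only" and "open" are said of these compounds alone.

Measured so far:
Compound 1, `CCN1CCN(c2cc(C)c3cc(NC(=O)c4ccc(C)cc4)ccc3n2)CC1`, gives 6740 nM in a functional assay on MCF7 cells (Homo sapiens) for antiproliferative activity, read by MTT assay, with a stated time of 72 h; a higher number here means a weaker inhibitor, a lower number a stronger inhibitor.
Compound 2, `Cc1cc(N2CCN(C)CC2)nc2ccc(NC(=O)c3ccc(Cl)c(Cl)c3)cc12`, gives 3000 nM in this assay.

Going by the values given here, of these two numbers, compound 2 stands at the lower end, and its gap to compound 1 is beyond the scatter; with only two compounds measured, nothing more can be read from the pair, and no single change links them.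

Compound 3, `CCN1CCN(c2cc(C)c3cc(NC(=O)c4ccc(Cl)c(Cl)c4)ccc3n2)CC1`, has not yet been measured in this assay. It differs from compound 2 in one place:

methyl in place of hydrogen on a saturated chain carbon bound to an amine nitrogen in a ring

The change is a small one, adding a single carbon to the chain on the ring nitrogen, while the rest of the molecule, including the dichlorophenyl amide shared with compound 2, stays the same. Among the compounds with values here, no measured pair shows what such a change does here. The expectation is that the step from compound 2 to compound 3 in this assay will be small, a 1.1-fold lower number from compound 2 to compound 3 (0.03 log units; within the scatter), most likely within the scatter and in no certain direction. On that basis compound 3 is estimated to give about 2800 nM, with a plausible range from 1000 nM to 7500 nM.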

Compound 3, half-maximal inhibitory concentration: 1380 nM
Compound 3: middle estimate off by 2.0-fold (0.31 log units), on the high side, and the stated range covers the measured number.
By their numbers in this assay, from the lowest: compound 3; then compound 2; then compound 1.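

In this assay, methyl in place of hydrogen on a saturated chain carbon bound to an amine nitrogen in a ring turns 4-methylpiperazin-1-yl into 4-ethylpiperazin-1-yl and brings a 2.2-fold lower number from compound 2 to compound 3 (0.34 log units; beyond the scatter). With 4-ethylpiperazin-1-yl held fixed, 3,4-dichlorophenyl in place of 4-methylphenyl on a carbonyl carbon brings a 4.9-fold lower number from compound 1 to compound 3 (0.69 log units; beyond the scatter), the first matched view of how the group on the carbonyl carbon affects this read-out. Nothing measured here explains either step.

As far as these compounds go, each change rests on a single pair, so it remains open whether the methyl step would appear with 4-methylphenyl on the carbonyl carbon, or the 3,4-dichlorophenyl step with 4-methylpiperazin-1-yl. From the compounds shown here alone, it is also open how the number would respond to a longer chain such as propyl on the ring nitrogen, to a bare hydrogen there, or to an unsubstituted phenyl on the carbonyl carbon.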